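From cyclopropyl to 1-(tert-butyl)azetidin-3-yl on one oxygen

The source may hold more compounds than are shown below. What is called first, only, known or untested is meant among the compounds shown, and "the series" means these compounds.

Measured in a functional assay on MCF7 cells (Homo sapiens) for antiproliferative activity, read by MTT assay, with a stated time of 48 h (on this read-out lower numbers stand for stronger inhibition and higher numbers for weaker inhibition), so far:
Compound 1 `CCOc1cc(-c2ccc3[nH]ccc3c2)cn2c(-c3cc(OC)c(OC)c(OC)c3)nnc12` gives 284 nM
Compound 2 `COc1cc(-c2nnc3c(OC4CC4)cc(-c4ccc5[nH]ccc5c4)cn23)cc(OC)c1OC` gives 259 nM

Among the measured compounds shown here, only two numbers exist so far, and the gap between them is small (a 1.1-fold lower number from compound 1 to compound 2 (0.04 log units; within the scatter)). Compound 2 therefore stands level with compound 1 and not ahead of it.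

Compound 3 `COc1cc(-c2nnc3c(OC4CN(C(C)(C)C)C4)cc(-c4ccc5[nH]ccc5c4)cn23)cc(OC)c1OC` keeps the shared core of compound 2 and alters one group, with 1-(tert-butyl)azetidin-3-yl in place of cyclopropyl on an oxygen on an aromatic ring. For the measured compounds named here, the only measured step at this oxygen, ethyl to cyclopropyl, stayed within the usual scatter of repeat measurements (a 1.1-fold lower number from compound 1 to compound 2 (0.04 log units; within the scatter)). Going by the values given here, that is a weak guide, since the new group is a much larger change, and no measured compound carries a nitrogen-containing ring here. In this assay a modest move towards a higher number is expected, probably not clearly beyond the scatter. The expected step is a 1.4-fold higher number from compound 2 to compound 3 (0.13 log units; within the scatter) in size. Compound 3 is estimated at 350 nM with an expected range from 100 nM to 1200 nM as the result to be tested.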

Compound 3, half-maximal inhibitory concentration: > 10000 nM
Compound 3: no number, only a limit (the forecaster's own chance of this, stated with the estimate: 3%); middle value at least 28-fold (1.45 log units) from the limit.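

Compound 3 has no exact number in this assay, only a limit: (the limit of > 10000 nM in this assay, at which 1 of the 3 values shown sits). Even read from that limit, the change at this oxygen is large and beyond the scatter, both against cyclopropyl (an at least 38-fold higher number from compound 2 to compound 3 (1.58 log units; beyond the scatter)) and against ethyl (an at least 35-fold higher number from compound 1 to compound 3 (1.54 log units; beyond the scatter)). The earlier step between ethyl and cyclopropyl suggested that this oxygen was indifferent to its substituent, whereas compound 3 shows that the group placed here can decide whether activity is detected at all in this assay.

The compounds shown change the ring, the nitrogen and the tert-butyl all at once, so they cannot say which of these goes with the loss of activity, or why it occurs. A cyclobutyl group, which has no nitrogen, and an azetidin-3-yl group without the tert-butyl would each separate part of this change, while a longer chain such as butyl would test a larger group without any ring.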